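The source may report more compounds than this note shows. Statements on the series, on what has been measured and on what is new or still open speak of the compounds shown alone.

Compound 1 `COc1ccc(CNc2ccc(-c3c(N)nc(N)nc3COCc3ccccc3)cc2)cc1` is the stronger of the two compounds measured in a functional assay on CHOK cells for antagonist activity at growth hormone secretagogue receptor type 1 (Homo sapiens), read by calcium flux (a lower number here means a stronger inhibitor, a higher number a weaker inhibitor), where compound 1 gives 90 nM. Among the compounds with values here, its only measured neighbour is compound 2 `Nc1nc(N)c(-c2ccc(NCc3cnc4ccccc4c3)cc2)c(COCc2ccccc2)n1`, which in this assay gives 780 nM; the step of an 8.7-fold higher number from compound 1 to compound 2 (0.94 log units; beyond the scatter) exchanged the aromatic ring carried on the saturated chain carbon bound to the ring nitrogen and weakened the inhibitor. Compound 3 `Nc1nc(N)c(-c2ccc(CNc3ccc([N+](=O)[O-])cc3)cc2)c(COCc2ccccc2)n1` is not yet measured. Within the data shown here, it departs from compound 1 by ((4-nitrophenyl)amino)methyl in place of (4-methoxybenzyl)amino on an aromatic carbon, a change of a different kind from the one measured step, since it reverses the order of the saturated carbon and the nitrogen in the link and exchanges the methoxy group for a nitro group. Among the measured compounds shown here, no measured pair speaks to that reversal directly; the one step that exists shows only that altering the group on this side of the shared core can cost potency. For compound 3 a loss of a similar or smaller size is therefore expected, a 3.9-fold higher number from compound 1 to compound 3 (0.59 log units; beyond the scatter). Compound 3 is thus estimated at 350 nM in this assay, within a range from 80 nM to 1600 nM.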

Compound 3, half-maximal inhibitory concentration: 16 nM
Beside the measured number, compound 3's estimate is 22-fold (1.34 log units) above it; measured number below the stated range.
By their numbers in this assay, from the lowest: compound 3; then compound 1; then compound 2.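

In this assay, the exchange of (4-methoxybenzyl)amino for ((4-nitrophenyl)amino)methyl gives a 5.6-fold lower number from compound 1 to compound 3 (0.75 log units; beyond the scatter), which shows that a change on this aromatic carbon, para to a large group, can strengthen the inhibitor, whereas the only earlier step, an 8.7-fold higher number from compound 1 to compound 2 (0.94 log units; beyond the scatter), had shown only a loss. This change alters two things at once: it reverses the order of the saturated carbon and the nitrogen in the link, and it puts a nitro group on the ring where a methoxy group stood, so this single step cannot assign the gain to either alteration. Nothing available here accounts for the gain.

The compounds shown leave open whether the reversed link would keep the lower number with a methoxy group on its ring, and whether a nitro group on the original link would give a similar gain. On these data alone, it also remains open how a nitrile or a carboxylic acid in the place of the nitro group would compare, and how this assay would respond to an amine in the place of the benzyloxymethyl group shared by all three compounds.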